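Compound 2 to compound 4: a change at the amine side chain

A few compounds are considered here, and "the series" means these few. Any claim that something is new, unique, unknown or untested is made for them only; others in the source may bear on it.

All readings so far come from an ADME assay on HEK293 cells (Homo sapiens) for cytotoxicity, read by ATP content, with a stated time of 6 h; on this read-out higher numbers stand for lower toxicity in this test and lower numbers for higher toxicity in this test. Compound 2 `CCCCNc1nc(N)nc2ccn(Cc3ccccn3)c12` gives > 24000 nM here, which is a limit and not a number. Compound 1 `CCCCNc1nc(N)nc2ccn(CCCc3ccccc3)c12` gives > 24000 nM here, also a limit. Compound 3 `CCCCNc1nc(N)nc2ccn(Cc3ccncc3)c12` gives > 24000 nM here, again a limit. Compound 2 therefore stands with the whole series: the limit of > 24000 nM in this assay, at which 3 of the 3 values shown sit, sums up the position.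

Compound 4 `Cc1nc(CNc2nc(N)nc3ccn(Cc4ccccn4)c23)cs1` differs from compound 2 as follows: 2-methyl-1,3-thiazol-4-yl in place of propyl on a saturated chain carbon bound to a nitrogen on an aromatic ring. In short, 2-methyl-1,3-thiazol-4-yl stands in place of propyl on a saturated chain carbon bound to a nitrogen on an aromatic ring.

Among the compounds with values here, no measured step touches that place. The nearest are a step that the two limits leave unreadable from compound 1 to compound 2 and a step that the two limits leave unreadable from compound 1 to compound 3 and a step that the two limits leave unreadable from compound 2 to compound 3, all made on a saturated chain carbon bound to an aromatic nitrogen. None of them has a readable size, so they offer no size or direction to carry over. No step beyond the scatter is expected in this assay, and no direction is expected either. The expected step is a number no higher from compound 2 to compound 4 (the limit leaves the size open) and rests on this absence of any readable change. For compound 4 the estimated half-maximal cytotoxic concentration is 24000 nM, with an expected range of 12000 nM to 48000 nM, and a report of only a limit is the likeliest outcome.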

Compound 4, half-maximal cytotoxic concentration: > 24000 nM
Compound 4: only a limit was reported; the forecaster's own chance of this, stated with the estimate: 80%; the middle value sits exactly at the limit.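

The step between compound 2 and compound 4 cannot be read: in this assay each of the two gives only a limit, not a number. The compounds shown leave open where the half-maximal cytotoxic concentration of compound 1, compound 2, compound 3 or compound 4 lies, and whether a change at either varied place shifts it.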